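Swapping a sulfonyl-linked imidazole for a direct imidazole link

The compounds below may be only part of what the source reports. "The series", "measured", "known", "first", "only" and "open" are said of these compounds alone.

Compound 2 `CCOC(=O)c1c(CS(=O)(=O)c2nccn2C)nc2cc(OC)c(OC)cc2c1-c1ccc(OC)c(OC)c1` is one of two measured compounds; in a functional assay on the whole organism for inhibition, with Rattus norvegicus as the target, at a dose of 50 mg/kg by the oral route (on this read-out higher numbers stand for more inhibition at the one dose given (going by the name of the read-out) and lower numbers for less inhibition), compound 2 gives 56%, while compound 1 `CCOC(=O)c1c(CSc2nncn2C)nc2cc(OC)c(OC)cc2c1-c1ccc(OC)c(OC)c1` gives 66%, the two sitting within the scatter of each other. Compound 3 `CCOC(=O)c1c(Cn2ccnc2CC)nc2cc(OC)c(OC)cc2c1-c1ccc(OC)c(OC)c1` differs from compound 2 by 2-ethyl-1H-imidazol-1-yl in place of (1-methyl-1H-imidazol-2-yl)sulfonyl on a saturated chain carbon bound to an aromatic carbon. Going by the values given here, the only step at this position, a number 10 percentage points lower from compound 1 to compound 2 (within the scatter), stayed inside the scatter, so no change beyond the scatter is expected for compound 3, that is a number 1 percentage points higher from compound 2 to compound 3 (within the scatter). Compound 3 is therefore estimated at 57%, between 38% and 75%.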

Compound 3, a percentage reported as inhibition, in the whole organism at one dose (the size of the read-out at that dose, not a potency): 65%
Compound 3: the middle estimate sits 8 percentage points below what was measured; measured number inside the range.
By their numbers in this assay, from the lowest: compounds 2, 3 and 1 (each within the scatter of the next).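

In this assay, the group on this saturated chain carbon changes again without leaving the scatter: a number 9 percentage points higher from compound 2 to compound 3 (within the scatter), and a number 1 percentage points lower from compound 1 to compound 3 (within the scatter). A 2-ethyl-1H-imidazol-1-yl group, which holds no sulfur, thus gives a number within the scatter of both sulfur-linked groups. Nothing measured here explains this result.

On these data alone, whether an amine or a carboxylic acid at this place would move the number beyond the scatter stays open. Also open, as far as these compounds go, is the separate contribution of the ethyl group and of the missing sulfonyl link, since both differ at once between compound 2 and compound 3.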